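One Group Exchanged on Compound 1

The source may hold more compounds than are shown below. What is called first, only, known or untested is meant among the compounds shown, and "the series" means these compounds.

Compound 1 `O=C1CCCN1c1cnc(NCc2c(F)ccc3c2CCO3)c2cn[nH]c(=O)c12` gives 1.8
Compound 2 `CN(c1ccn(C)n1)c1cnc(NCc2c(F)ccc3c2CCO3)n2cnnc12` gives 1.8

In a physicochemical assay for lipophilicity, using the shake flask method, in phosphate buffer, measured as octanol-water partition, with a stated time of 30 min, at pH 7.4 (on this read-out lower numbers stand for lower lipophilicity and higher numbers for higher lipophilicity), compound 1 stands level with compound 2, with no change at the digits shown and a gap within the usual scatter. Compound 3 `CNC(=O)c1cc(-c2cnc(NCc3c(F)ccc4c3CCO4)c3cn[nH]c(=O)c23)n(C)n1` keeps the core of compound 1 and carries 1-methyl-3-(methylcarbamoyl)-1H-pyrazol-5-yl in place of 2-oxopyrrolidin-1-yl on an aromatic carbon. For the measured compounds named here, no measured pair here isolates a change at one place, so guidance is thin. The only hint is that a structure quite unlike compound 1, namely compound 2 (1.8), reaches the same number. A shift beyond the scatter is therefore not expected, with only a slight lean upward. The estimated step (a number 0.10 log units higher from compound 1 to compound 3 (within the scatter)) is expected to stay within the usual scatter. The expected value for compound 3 is 1.9 (estimated range 1.4 to 2.4).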

Compound 3, distribution coefficient: 2.1
Compound 3: middle estimate off by 0.20 log units, on the low side; measured number inside the range.
By their numbers in this assay, from the lowest: compounds 1, 2 and 3 (each within the scatter of the next).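

For the compounds shown here, this is the first step read at a single place, on an aromatic carbon of the shared core. In this assay, 1-methyl-3-(methylcarbamoyl)-1H-pyrazol-5-yl in place of 2-oxopyrrolidin-1-yl gives a number 0.30 log units higher from compound 1 to compound 3 (within the scatter), so compound 1 and compound 3 cannot be told apart on this read-out. The entering group has 10 heavy atoms against 6 and brings a hydrogen-bond donor, yet this larger exchange does not carry the number beyond the scatter, and nothing available explains why.

This single step swaps the ring and the methylcarbamoyl chain together, so it cannot show what each contributes alone. Going by these compounds, whether the read-out would stay within the scatter with a carboxylic acid or an amine at this place remains open.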